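A few compounds are considered here, and "the series" means these few. Any claim that something is new, unique, unknown or untested is made for them only; others in the source may bear on it.

Compound 1 `COc1ccc(C(=O)/C=C/c2ccc(OCC=C(C)C)c(OC)c2)cc1OC` gives 1750000 nM
Compound 2 `COc1cc(/C=C/C(=O)c2ccc(OC/C=C(\C)CCC=C(C)C)c(OC)c2)ccc1OCC=C(C)C` gives 825000 nM

Both values come from an ADME assay on J774.A1 cells (Mus musculus) for cytotoxicity, read by MTT assay, with a stated time of 20 h (on this read-out higher numbers stand for lower toxicity in this test and lower numbers for higher toxicity in this test), and compound 2 holds the lower number of the two. Compound 3 `COc1cc(/C=C/C(=O)c2ccc(OC/C=C(\C)CCC=C(C)C)c(OC)c2)ccc1OC/C=C(\C)CCC=C(C)C` has not yet been measured. It differs from compound 2 by 3-methylbut-2-en-1-yl in place of hydrogen on a saturated chain carbon bound to a double-bonded chain carbon and this turns a (3-methylbut-2-en-1-yl)oxy group into a (3,7-dimethylocta-2,6-dien-1-yl)oxy group. Within the data shown here, only one measured step bears on this change, namely a 2.1-fold lower number from compound 1 to compound 2 (0.33 log units; beyond the scatter) where 2,6-dimethylhepta-1,5-dien-1-yl took the place of hydrogen on a saturated chain carbon bound to an oxygen on an aromatic ring. That is a single modest step and thin support. A similar lowering is nevertheless expected, with a 1.8-fold lower number from compound 2 to compound 3 (0.26 log units; within the scatter) as the estimate in this assay for this change. Compound 3 is expected at 450000 nM within a range from 180000 nM to 1100000 nM by this estimate.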

Compound 3, half-maximal cytotoxic concentration: 1020000 nM
Compound 3: middle estimate off by 2.3-fold (0.36 log units), on the low side, and the stated range covers the measured number.
By their numbers in this assay, from the lowest: compounds 2, 3 and 1 (each within the scatter of the next, the first and the last beyond it).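

In this assay, extending the (3-methylbut-2-en-1-yl)oxy group to the (3,7-dimethylocta-2,6-dien-1-yl)oxy group gives a 1.2-fold higher number from compound 2 to compound 3 (0.09 log units; within the scatter) and so leaves the number within the usual spread of repeat measurements. The earlier step of a 2.1-fold lower number from compound 1 to compound 2 (0.33 log units; beyond the scatter) lay beyond that spread but was made in a different place on the molecule, and a clear shift of that kind does not appear for this change. Nothing available explains why the two changes differ.

As far as these compounds go, it remains open whether a saturated octyl chain or a chain ending in a carboxylic acid, in place of the (3,7-dimethylocta-2,6-dien-1-yl)oxy group, would shift the number. These compounds also leave open whether the same picture would hold in cells other than this mouse line.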